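The source may hold more compounds than are shown below. What is called first, only, known or untested is meant among the compounds shown, and "the series" means these compounds.

In a functional assay on NCI-H460 cells (Homo sapiens) for cytotoxicity, read by MTT assay, with a stated time of 72 h (a lower number here means a stronger inhibitor, a higher number a weaker inhibitor), compound 1 `COc1cc2c(Oc3ccc(NC(=O)c4cc(-c5ccccc5)ccn4)cc3F)ccnc2cc1OCCCN1CCN(C)CC1` gives 91 nM. Compound 2 `COc1cc2c(Oc3ccc(NC(=O)c4cc(-c5ccc(F)cc5)ccn4)cc3F)ccnc2cc1OCCCN1CCN(C)CC1` carries the change (fluoro in place of hydrogen on an aromatic carbon), placed para to a large group, and shows a 4.7-fold higher number from compound 1 to compound 2 (0.67 log units; beyond the scatter), so in this assay compound 2 gives 430 nM. Compound 3 `COc1cc2c(Oc3ccc(NC(=O)c4nccc(-c5ccc(F)cc5)n4)cc3F)ccnc2cc1OCCCN1CCN(C)CC1` rests on a different core; the difference between the two cores is not broken down here. In this assay compound 3 gives 63 nM. Compound 4 `COc1cc2c(Oc3ccc(NC(=O)c4nccc(-c5ccc(F)cc5F)n4)cc3F)ccnc2cc1OCCCN1CCN(C)CC1` differs from compound 3 by fluoro in place of hydrogen on an aromatic carbon, the same kind of change, but here the entering fluoro sits ortho to a large group and meta to a fluoro group rather than para to a large group. Because a 4.7-fold higher number from compound 1 to compound 2 (0.67 log units; beyond the scatter) was a modest loss at a different place, a smaller loss is expected here, a 2.1-fold higher number from compound 3 to compound 4 (0.31 log units; beyond the scatter). Compound 4 is therefore estimated at about 130 nM, expected between 50 nM and 400 nM.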

Compound 4, half-maximal inhibitory concentration: 450 nM
Compound 4: the middle estimate sits 3.5-fold (0.54 log units) below what was measured; the whole stated range lies below it.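

In this assay, the new step gives a 7.1-fold higher number from compound 3 to compound 4 (0.85 log units; beyond the scatter), and it matches the earlier step in size: the same change on two cores in this assay, a 4.7-fold higher number (0.67 log units; beyond the scatter) from compound 1 to compound 2 and a 7.1-fold higher number (0.85 log units; beyond the scatter) from compound 3 to compound 4, 1.5-fold (0.18 log units) apart, within the scatter of two such steps. Adding a fluoro to the carbon-only aromatic ring therefore weakens the compound on both cores, so here the loss carries from the core of compound 1 to the core of compound 3. This does not show that the two cores respond alike at the same place, since the fluoro enters at a different place in each step, and two steps in one assay make no general rule.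

The compounds shown leave open whether a chloro, a methoxy or an amine on this ring would bring a similar loss. They also leave open whether the loss appears in other cell lines.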